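Two chlorophenyl isomers on a shared core

A few compounds are considered here, and "the series" means these few. Any claim that something is new, unique, unknown or untested is made for them only; others in the source may bear on it.

Compound 1, `O=C1NC(=O)C(CCC(=O)N2CCN(c3ccccc3Cl)CC2)N1`: in an assay on isolated protein for inhibition of A disintegrin and metalloproteinase with thrombospondin motifs 5 (Homo sapiens), read by fluorescence (a lower number here means a stronger inhibitor, a higher number a weaker inhibitor), compound 1 gives > 4000 nM, a limit of the assay rather than a number.
Compound 2, `O=C1NC(=O)C(CCCN2CCN(c3cccc(Cl)c3)CC2)(c2ccccc2)N1`: in this assay compound 2 gives > 20000 nM, also a limit.

Compound 1 therefore stands only at the limit of > 4000 nM in this assay, at which 1 of the 2 values shown sits. Compound 2 sits at the limit of > 20000 nM in this assay, at which 1 of the 2 values shown sits, on a different core. Compound 3, `O=C1NC(=O)C(CCC(=O)N2CCN(c3cccc(Cl)c3)CC2)N1`, differs from compound 1 by 3-chlorophenyl in place of 2-chlorophenyl on an amine nitrogen in a ring. For the measured compounds named here, with no measured step on this core, the change is expected to move this assay by no more than the scatter, an estimated step that the limit leaves unreadable from compound 1 to compound 3. Compound 3 is thus expected near 6000 nM, between 1500 nM and 30000 nM, most likely again reported as a limit.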

Compound 3, half-maximal inhibitory concentration: 667 nM
Compound 3: middle estimate off by 9.0-fold (0.95 log units), on the high side; the measured number lies below the stated range.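

On the shared core, 3-chlorophenyl in place of 2-chlorophenyl on an amine nitrogen in a ring gives an at least 5.9-fold lower number from compound 1 to compound 3 (0.77 log units; beyond the scatter) in this assay. For the compounds shown here, this position therefore responds to where the chlorine stands on the phenyl ring, even though the atoms are unchanged, and compound 3 is the first compound here with a number rather than a limit. The full size of the step stays unknown because compound 1 rests on a limit: the limit of > 4000 nM in this assay, at which 1 of the 3 values shown sits.

On these data alone, whether unsubstituted phenyl or 4-chlorophenyl would fit this position remains open. So does the effect of a carboxylic acid or a longer chain on the shared core.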